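Bromo for fluoro on the shared core of compound 1

The compounds below may be only part of what the source reports. "The series", "measured", "known", "first", "only" and "open" are said of these compounds alone.

Compound 1 `O=C(Cc1cccnc1)c1cc2cc(F)ccc2[nH]1` gives 36000 nM in an assay on isolated protein for inhibition of Indoleamine 2,3-dioxygenase 1 (Homo sapiens), read by spectrophotometry (on this read-out higher numbers stand for weaker inhibition and lower numbers for stronger inhibition), the lowest of the three numbers measured. Compound 2 `O=C(Cc1cccnc1)c1cc2c(O)cccc2[nH]1` gives 83000 nM and compound 3 `O=C(Cc1cccnc1)c1cc2cc(-c3ccccc3)ccc2[nH]1` gives 96000 nM. The change to compound 4 `O=C(Cc1cccnc1)c1cc2cc(Br)ccc2[nH]1` is bromo in place of fluoro on an aromatic carbon. Among the compounds with values here, the only measured step at this position is a 2.7-fold higher number from compound 1 to compound 3 (0.43 log units; beyond the scatter), a much larger group than bromo entering, so it bears on the new step only loosely; no halogen-to-halogen exchange has been measured. The expected step is therefore a 1.2-fold lower number from compound 1 to compound 4 (0.08 log units; within the scatter), not clearly beyond the scatter in either direction. Compound 4 is estimated at 30000 nM, with a range from 10000 nM to 90000 nM.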

Compound 4, half-maximal inhibitory concentration: 18000 nM
Estimate against measurement, compound 4: 1.7-fold (0.22 log units) above; low and high end bracket the measured number.
By their numbers in this assay, from the lowest: compounds 4 and 1 (each within the scatter of the next); then compounds 2 and 3 (each within the scatter of the next).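

At this position on the shared core, the halogen exchange gives a 2.0-fold lower number from compound 1 to compound 4 (0.30 log units; within the scatter) and so does not separate fluoro from bromo in this assay. The second comparison gives a 5.3-fold lower number from compound 3 to compound 4 (0.73 log units; beyond the scatter) and shows that bromo, like fluoro, stands apart from phenyl beyond the scatter. No evidence in hand accounts for these differences.

Open, on these data alone, is whether chloro or iodo would stay within the scatter of the two halogens seen here. Also open, as far as these compounds go, is how a small non-halogen group, such as methoxy or an amine, would read at this position.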